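This account rests on a few compounds, and the source may have more. Where it says the series, first, only, none or still open, it means among the compounds named here.

compound 1 `CCn1cc(-c2nc3ccccc3[nH]2)c(=O)c2cc(F)c(N3CCN(C)CC3)cc21` — > 5010000 nM
compound 2 `CCn1cc(-c2nc3ccccc3o2)c(=O)c2cc(F)c(N3CCN(C)CC3)cc21` — 700 nM
compound 3 `CCn1cc(-c2nc3ccccc3s2)c(=O)c2cc(F)c(N3CCN(C)CC3)cc21` — 114000 nM
compound 4 `CCn1cc(-c2nc3ccc([N+](=O)[O-])cc3[nH]2)c(=O)c2cc(F)c(N3CCN(C)CC3)cc21` — not yet measured

Of the compounds shown here, three have been read in a functional assay on A2780 cells (Homo sapiens) for cytotoxicity, read by MTT assay, with a stated time of 48 h; on this read-out lower numbers stand for stronger inhibition and higher numbers for weaker inhibition. For compound 1 the value > 5010000 nM is a limit of the assay, not a number (the limit of > 5010000 nM in this assay, at which 1 of the 3 values shown sits). Compound 2 gives 700 nM and compound 3 gives 114000 nM. The measured steps are an at least 7100-fold lower number from compound 1 to compound 2 (3.85 log units; beyond the scatter), an at least 43-fold lower number from compound 1 to compound 3 (1.64 log units; beyond the scatter) and a 160-fold higher number from compound 2 to compound 3 (2.21 log units; beyond the scatter), all large. Compound 1 therefore stands at the weak end of the three, known only as a limit.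

The step to compound 4 is nitro in place of hydrogen on an aromatic carbon. Among the measured compounds shown here, none of the measured steps concerns this change: all three exchange the whole group attached to the shared core, whereas here the 1H-benzimidazol-2-yl is kept and nitro is added to it. For the measured compounds named here, compound 1 is the only carrier of that group, and its value is a limit, so the starting point is itself not a number. Going by the values given here, with no step bearing on the change, no direction beyond the scatter can be expected; compound 4 is estimated at 5000000 nM, range 500000 nM to 50000000 nM. The step of a number no higher from compound 1 to compound 4 (the limit leaves the size open) is what this estimate expects, with a real chance that only a limit is reported again.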

Compound 4, half-maximal inhibitory concentration: 4700 nM
The estimate for compound 4 lay 1100-fold (3.03 log units) above the measured number; the measured number lies below the stated range.
By their numbers in this assay, from the lowest: compound 2; then compound 4; then compound 3. At a limit, above all of these: compound 1.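

In this assay, nitro on an aromatic carbon of the six-membered aromatic ring of carbon only gives an at least 1000-fold lower number from compound 1 to compound 4 (3.02 log units; beyond the scatter), the only change shown that keeps the 1H-benzimidazol-2-yl in place. This aromatic carbon is therefore a site where one added group moves the number far, without any exchange of the whole group attached to the shared core. The value of compound 1 is a limit and not a number, so the step has a lower bound but no exact size: the limit of > 5010000 nM in this assay, at which 1 of the 4 values shown sits.

Open, going by these compounds, is whether this drop belongs to nitro itself or would also follow an amine or a chlorine on the same carbon. Also open, on these data alone, is whether nitro on the 1,3-benzoxazol-2-yl of compound 2 would lower its number further.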